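Chloro for Bromo on Two Different Cores

A few compounds are considered here, and "the series" means these few. Any claim that something is new, unique, unknown or untested is made for them only; others in the source may bear on it.

Compound 1 `Cc1ccc(CS/C(=C/c2c[nH]c3ccc(Br)cc23)C(=O)c2ccc(Cl)cc2)cc1` and compound 2 `Cc1ccc(CS/C(=C/c2c[nH]c3ccc(Cl)cc23)C(=O)c2ccc(Cl)cc2)cc1` share one core; compound 3 `COc1ccc(C(=O)/C(=C\c2ccc(Br)cc2)Sc2ccc(F)cc2)cc1` and compound 4 `COc1ccc(C(=O)/C(=C\c2ccc(Cl)cc2)Sc2ccc(F)cc2)cc1` share another, and the difference between the two cores is not broken down here. In a functional assay on DU-145 cells (Homo sapiens) for inhibition, read by trypan blue exclusion, with a stated time of 96 h (a higher number here means a weaker inhibitor of growth, a lower number a stronger inhibitor of growth), compound 1 gives 1000 nM, and compound 2 gives 1000 nM. The change from compound 1 to compound 2 is chloro in place of bromo on an aromatic carbon, and it made the step of no change at the digits printed from compound 1 to compound 2 (within the scatter). For compound 3 only a limit is known: in this assay compound 3 gives > 100000 nM, a limit of the assay and not a number, namely (the limit of > 100000 nM in this assay, at which 1 of the 3 values shown sits). Compound 4 carries the same kind of change, (chloro in place of bromo on an aromatic carbon); the place differs, here on a six-membered aromatic ring of carbon only, para to a large group, where before it was part of a fused or bridged system of two rings, meta to a fused ring and para to a fused ring. Because the measured step of no change at the digits printed from compound 1 to compound 2 (within the scatter) stayed within the scatter, a similar outcome is expected for compound 4, with the estimated step of a number no higher from compound 3 to compound 4 (the limit leaves the size open). In this assay compound 4 is expected to give 100000 nM.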

Compound 4, concentration for 50% growth inhibition: > 100000 nM
Compound 4: a limit, no number; the forecaster's own chance of this, stated with the estimate: 70%; the middle value sits exactly at the limit.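

In this assay, compound 3 and compound 4 are each known only as a limit and not as a number, so no step can be read between them: the limit of > 100000 nM in this assay, at which 2 of the 4 values shown sit. The compounds shown leave open whether chloro in place of bromo changes growth inhibition at all on the core of compound 3.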